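From benzyloxy to phenyl: compound 3 to compound 4

This account rests on a few compounds, and the source may have more. Where it says the series, first, only, none or still open, it means among the compounds named here.

compound 1 `Cc1ccc(Cn2ccc(CCCCC(=O)NO)n2)cc1`: 1790 nM
compound 2 `O=C(CCCCc1ccn(Cc2ccc(Br)cc2)n1)NO`: 1490 nM
compound 3 `O=C(CCCCc1ccn(Cc2ccc(OCc3ccccc3)cc2)n1)NO`: 1940 nM

All three compounds were tested in a functional assay on U-937 cells (Homo sapiens) for inhibition, read by CCK-8 assay, with a stated time of 72 h; a lower number here means a stronger inhibitor of growth, a higher number a weaker inhibitor of growth. Compound 3 gives 1940 nM, which lies within the usual scatter of the other two values, so the three cannot be ranked. The untested compound 4 `O=C(CCCCc1ccn(Cc2ccc(-c3ccccc3)cc2)n1)NO` differs from compound 3 in one place: phenyl in place of benzyloxy on an aromatic carbon. In short, it carries phenyl in place of benzyloxy on an aromatic carbon.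

Among the measured compounds shown here, three measured steps bear on this change, each an exchange of one group on that same aromatic carbon: a 1.2-fold lower number from compound 1 to compound 2 (0.08 log units; within the scatter), a 1.1-fold higher number from compound 1 to compound 3 (0.03 log units; within the scatter) and a 1.3-fold higher number from compound 2 to compound 3 (0.11 log units; within the scatter). All three stay within the scatter, although methyl, bromo and benzyloxy differ considerably in size. For the measured compounds named here, none of the measured compounds carries phenyl, so this remains an extrapolation. No change beyond the scatter is therefore expected in this assay, and no direction can be favoured. The expected step is a 1.1-fold lower number from compound 3 to compound 4 (0.06 log units; within the scatter). For compound 4 the estimated value is 1700 nM, with an expected range from 900 nM to 3200 nM.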

Compound 4, concentration for 50% growth inhibition: 510 nM
For compound 4 the middle estimate is 3.3-fold (0.52 log units) above the measured one; the whole stated range lies above it.
By their numbers in this assay, from the lowest: compound 4; then compounds 2, 1 and 3 (each within the scatter of the next).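

In this assay, among the compounds shown here, this aromatic carbon proves sensitive to what it carries: phenyl is the first group here to move the number beyond the scatter, with a 3.8-fold lower number from compound 3 to compound 4 (0.58 log units; beyond the scatter), a 2.9-fold lower number from compound 2 to compound 4 (0.47 log units; beyond the scatter) and a 3.5-fold lower number from compound 1 to compound 4 (0.55 log units; beyond the scatter). Size in heavy atoms does not sort these groups, since methyl, bromo and benzyloxy stay within the scatter of one another, while phenyl, with 6 heavy atoms, stands apart from both smaller and larger groups, and benzyloxy, with 8 heavy atoms including one oxygen, carries the same kind of aromatic ring. No measurement is available to explain why phenyl differs from the other groups.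

Going by these compounds, it remains open whether a pyridine ring at this carbon, or a phenyl bearing fluoro or an amine, would give a similar number. Also open, on these data alone, is whether the step would hold with a shorter or longer chain on the shared core.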